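Pyridyl hydrazone in place of difluorophenyl on the shared core

This account rests on a few compounds, and the source may have more. Where it says the series, first, only, none or still open, it means among the compounds named here.

Measured so far in an ADME assay on HT-29 cells (Homo sapiens) for inhibition, read by MTT assay, with a stated time of 72 h; a higher number here means a weaker inhibitor, a lower number a stronger inhibitor:
compound 1 `C=CC(=O)Nc1cccc(Nc2nc(N/N=C/c3ccc(F)cc3F)ncc2Cl)c1` gives 4760 nM;
compound 2 `C=CC(=O)Nc1cccc(Nc2nc(N/N=C(\C)c3ccc(OC)cc3)ncc2Cl)c1` gives 4560 nM;
compound 3 `CN(C)C/C=C/C(=O)Nc1cccc(Nc2nc(N/N=C/c3ccc(F)cc3F)ncc2Cl)c1` gives 2920 nM.

Compound 3 has the lowest number of the three, though its gaps to compound 2 and compound 1 both lie within the scatter. Compound 4 `C/C(=N\Nc1ncc(Cl)c(Nc2cccc(NC(=O)/C=C/CN(C)C)c2)n1)c1ccncc1` differs from compound 3 by a group of 9 heavy atoms (7 carbon, 2 nitrogen; one six-membered aromatic ring with 1 hetero atom) in place of a group of 10 heavy atoms (7 carbon, 1 nitrogen, 2 fluorine; one six-membered aromatic ring of carbon only), on a nitrogen on an aromatic ring. For the measured compounds named here, the only step measured, a 1.6-fold lower number from compound 1 to compound 3 (0.21 log units; within the scatter), concerns the amide side and does not bear on this change; compound 1 and compound 2, which differ at the hydrazone aryl group among other places, show values within the scatter of each other. No step beyond the scatter is therefore expected for a 1.0-fold higher number from compound 3 to compound 4 (0.01 log units; within the scatter). Compound 4 is estimated at 3000 nM, within 1200 nM to 8000 nM.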

Compound 4, half-maximal inhibitory concentration: 10900 nM
Estimate against measurement, compound 4: 3.6-fold (0.56 log units) below; the whole stated range lies below it.
By their numbers in this assay, from the lowest: compounds 3, 2 and 1 (each within the scatter of the next); then compound 4.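

In this assay, for the compounds shown here, this is the first change to give a step beyond the scatter, a 3.7-fold higher number from compound 3 to compound 4 (0.57 log units; beyond the scatter), so the group on this nitrogen on an aromatic ring does affect the read-out, and compound 4 is the weaker inhibitor of the pair. The earlier step on the amide side stayed within the scatter, a 1.6-fold lower number from compound 1 to compound 3 (0.21 log units; within the scatter). No available data explain the loss.

The swap replaces a ring of carbon only and 2 fluorine with a ring with 1 hetero atom, so the compounds shown cannot separate these parts. On these data alone, a plain phenyl group here would help, and whether the swap gives a similar step with the vinyl amide of compound 1 also remains open.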